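Bromo in place of chloro on compound 2

The compounds below may be only part of what the source reports. "The series", "measured", "known", "first", "only" and "open" are said of these compounds alone.

In a functional assay on HCT-116 cells (Homo sapiens) for inhibition, read by CCK-8 assay, with a stated time of 48 h (on this read-out lower numbers stand for stronger inhibition and higher numbers for weaker inhibition), compound 1 (`COc1ccc(CN(C(=O)CSC(=S)N2CCN(C(=O)OC(C)(C)C)CC2)c2cc(OC)c(OC)c(OC)c2)cc1`) gives 620 nM. Compound 2 (`COc1ccc(CN(C(=O)CSC(=S)N2CCN(C(=O)OC(C)(C)C)CC2)c2ccc(Cl)cc2)cc1`) gives > 20000 nM, which is a limit and not a number. Compound 3 (`COc1ccc(CN(C(=O)CSC(=S)N2CCN(C(=O)OC(C)(C)C)CC2)c2ccc(Br)cc2)cc1`) differs from it by bromo in place of chloro on an aromatic carbon, para to a large group. For the measured compounds named here, the only measured step, an at least 32-fold higher number from compound 1 to compound 2 (1.50 log units; beyond the scatter), is large, but it exchanges 3,4,5-trimethoxyphenyl for 4-chlorophenyl and does not test bromo against chloro. No step beyond the scatter is therefore expected in this assay. The expected step runs a step that the limit leaves unreadable from compound 2 to compound 3. For compound 3 the estimate is 22000 nM, with an expected range of 9000 nM to 40000 nM.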

Compound 3, half-maximal inhibitory concentration: > 20000 nM
Compound 3: a limit, no number; the forecaster's own chance of this, stated with the estimate: 70%; the middle value does not contradict the limit.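

In this assay compound 3 gives > 20000 nM, which is a limit and not a number. Replacing 3,4,5-trimethoxyphenyl with 4-bromophenyl on the amide-type nitrogen gives an at least 32-fold higher number from compound 1 to compound 3 (1.50 log units; beyond the scatter), so the large loss seen with 4-chlorophenyl recurs with a second halogen on this aromatic carbon. The step between the two halogen compounds cannot be read, and bromo and chloro cannot be ranked here: the limit of > 20000 nM in this assay, at which 2 of the 3 values shown sit.

Still open, from the compounds shown here alone, is whether any single-substituted phenyl ring at this nitrogen reaches a measurable value. An amine or a carboxylic acid in place of the halogen would test this.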